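Hydroxy for methoxy on compound 1: working notes

A few compounds are considered here, and "the series" means these few. Any claim that something is new, unique, unknown or untested is made for them only; others in the source may bear on it.

Compound 1 `COc1cc(/C=C/c2nc3cc(Cl)cnc3n(CC(=O)O)c2=O)ccc1O` is the only entry in this series with a numeric read-out: in a functional assay, read by spectrophotometry, with a stated time of 30 min, tested at 50 uM (on this read-out higher numbers stand for a stronger effect at the one concentration tested and lower numbers for a weaker effect), compound 1 gives 81.8%. Within the data shown here, two further entries carry no number; in this assay compound 2 `COc1c(O)cc(-c2nc3cccnc3n(CC(=O)O)c2=O)cc1O` gives "not determined" (no result reported) and compound 3 `COc1ccc(-c2nc3cccnc3n(CC(=O)O)c2=O)cc1O` gives "not determined" (no result reported), so neither offers a reference point, and no step between measured compounds is available.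

Compound 4 `O=C(O)Cn1c(=O)c(/C=C/c2ccc(O)c(O)c2)nc2cc(Cl)cnc21` is the next entry. Relative to compound 1 it differs in one place:
hydrogen in place of methyl on an oxygen on an aromatic ring
Cut one bond further out, the same difference reads methoxy to hydroxy, the 4-hydroxy-3-methoxyphenyl of compound 1 becoming 3,4-dihydroxyphenyl.

With nothing measured on either side of this change, the expectation rests on compound 1 alone, whose read-out of 81.8% already sits high. The expected step of a number 3.2 percentage points higher from compound 1 to compound 4 (within the scatter) is estimated to stay within the usual scatter, with at most a slight lean upward. Compound 4 is therefore expected to give 85% in this assay, estimated between 70% and 96%.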

Compound 4, a percentage reported as activity, at one concentration (the size of the read-out at that concentration, not a potency): 87.4%
For compound 4 the middle estimate is 2.4 percentage points below the measured one, and the stated range covers the measured number.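

In this assay, among these compounds, the change from 4-hydroxy-3-methoxyphenyl to 3,4-dihydroxyphenyl gives a number 5.6 percentage points higher from compound 1 to compound 4 (within the scatter) and so leaves the read-out high, which is the first sign that this oxygen keeps its effect without the methyl. At the one concentration tested, compound 1 and compound 4 cannot be told apart, so the methyl is not needed for the read-out at this position. No measurement on hand bears on why the read-out holds after this change.

As far as these compounds go, whether a longer chain on this oxygen, such as ethoxy, or an amine in place of the hydroxy keeps the read-out remains open. Compounds 2 and 3 carry no number, so they cannot show whether the same change behaves alike in their setting, and a single-concentration read-out gives no potency for either compound 1 or compound 4.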